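This account rests on a few compounds, and the source may have more. Where it says the series, first, only, none or still open, it means among the compounds named here.

The measured compounds so far:
compound 1, `COc1ccc(N2CCN(C(=S)SCc3ccc(C(=O)Nc4ccccc4N)cc3)CC2)cc1`, which in a functional assay on MGC-803 cells (Homo sapiens) for antiproliferative activity, read by CCK-8 assay, with a stated time of 72 h, tested at 8 uM (a lower number here means a weaker effect, a higher number a stronger effect of the compound at the concentration tested), gives 22.9%;
compound 2, `Cc1ccc(N2CCN(C(=S)SCc3ccc(C(=O)Nc4ccccc4N)cc3)CC2)cc1`, which in this assay gives 19.8%.

Compound 2 stands alongside compound 1 on these two numbers: the step of a number 3.1 percentage points lower from compound 1 to compound 2 (within the scatter) is within the scatter, so the two compounds are not told apart by this measurement. Compound 3, `Nc1ccccc1NC(=O)c1ccc(CSC(=S)N2CCN(c3ccncc3)CC2)cc1`, has not yet been measured. It differs from compound 2 by pyridin-4-yl in place of 4-methylphenyl on an amine nitrogen in a ring. Within the data shown here, no measured step covers a change of this kind. Among the measured compounds shown here, the only step recorded, a number 3.1 percentage points lower from compound 1 to compound 2 (within the scatter), concerns methyl in place of methoxy on an aromatic carbon, a change at a different place, and it stayed within the scatter. There is thus no basis for expecting a move in this assay beyond the scatter in either direction, and the estimate for compound 3 rests on the number of compound 2. Compound 3 is therefore expected to give 21%, within a range from 9% to 34%. The step that this estimate implies, a number 1.2 percentage points higher from compound 2 to compound 3 (within the scatter), is expected to lie within the scatter.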

Compound 3, a percentage reported as inhibition, at one concentration (the size of the read-out at that concentration, not a potency): 87.1%
Compound 3: the middle estimate sits 66.1 percentage points below what was measured, and the stated range ends below it.
By their numbers in this assay, from the lowest: compounds 2 and 1 (each within the scatter of the next); then compound 3.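

In this assay, the group on the amine nitrogen in the ring proves to be a place where the read-out can move far: pyridin-4-yl in place of 4-methylphenyl gives a number 67.3 percentage points higher from compound 2 to compound 3 (beyond the scatter), and pyridin-4-yl in place of 4-methoxyphenyl gives a number 64.2 percentage points higher from compound 1 to compound 3 (beyond the scatter). The earlier exchange of methyl for methoxy on the aromatic ring at this end of the molecule had not separated compound 1 from compound 2, whereas both steps to compound 3, which put a nitrogen into that aromatic ring and leave no methyl or methoxy group on it, lie well beyond the scatter. Nothing available here accounts for the size of these steps.

Since both steps change the ring atoms and remove the group on the ring together, the compounds shown do not tell which of the two matters, and plain phenyl on the same nitrogen would stand between those readings. On these data alone, it also remains open how pyridin-3-yl or pyridin-2-yl would compare with pyridin-4-yl, and so whether the place of the ring nitrogen matters or only its presence.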